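Taking the bromo group off compound 2

This account rests on a few compounds, and the source may have more. Where it says the series, first, only, none or still open, it means among the compounds named here.

- compound 1 `CN(C)C(=O)c1cc2cnc(Nc3ccc(NC(=O)C4(C(=O)Nc5ccc(Cl)cc5)CC4)cc3)nc2n1C1CCCC1`: -0.8%
- compound 2 `CN(C)C(=O)c1cc2cnc(Nc3ccc(NC(=O)C4(C(=O)Nc5ccc(Br)cc5)CC4)cc3)nc2n1C1CCCC1`: 23.2%

In a functional assay on SiHa cells (Homo sapiens) for inhibition, read by CCK-8 assay, with a stated time of 72 h, tested at 1 uM (on this read-out lower numbers stand for less inhibition of growth and higher numbers for more inhibition of growth at the one concentration tested), compound 2 stands highest of the two at 23.2% and compound 3 `CN(C)C(=O)c1cc2cnc(Nc3ccc(NC(=O)C4(C(=O)Nc5ccccc5)CC4)cc3)nc2n1C1CCCC1` remains unmeasured. It differs from compound 2 by hydrogen in place of bromo on an aromatic carbon with hydrogen in place of bromo on an aromatic carbon. Among the measured compounds shown here, one measured step bears on this change: a number 24 percentage points higher from compound 1 to compound 2 (beyond the scatter) for bromo in place of chloro. For the measured compounds named here, no compound without a halogen there has been measured, so the guide is thin. In this assay a modest drop is expected, and the estimate is a number 15.2 percentage points lower from compound 2 to compound 3 (beyond the scatter) in size. For compound 3 the expected value is 8% within an estimated range of -8% to 26%.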

Compound 3, percent growth inhibition at one concentration: 58%
Compound 3: the middle estimate sits 50 percentage points below what was measured, outside the stated range (above it).
By their numbers in this assay, from the lowest: compound 1; then compound 2; then compound 3.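

In this assay, hydrogen gives the highest number of the three at this place on the aromatic ring: a number 34.8 percentage points higher from compound 2 to compound 3 (beyond the scatter), and a number 58.8 percentage points higher from compound 1 to compound 3 (beyond the scatter). The earlier pair showed only that bromo stood above chloro, whereas both halogens now stand below the unsubstituted phenyl. Nothing available explains this order. 

On these data alone, it remains open whether a smaller fluoro, a methyl or a methoxy at this place would stay close to compound 3 or fall towards the halogen compounds. As far as these compounds go, the order at other concentrations also remains open.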